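Replacing pentan-3-yl with phenyl in compound 1

The source may hold more compounds than are shown below. What is called first, only, known or untested is meant among the compounds shown, and "the series" means these compounds.

In an ADME assay on microsomes from liver (Homo sapiens) for metabolic stability (a higher number here means that the compound lasts longer, a lower number that the compound disappears faster), compound 1 (`CCC(CC)C(/C=C1\OC(=O)NC1=O)c1ccc(-c2ccc3cccc(F)c3c2)[nH]c1=O`) gives > 3 h, which is a limit of the assay and not a number. In this assay compound 2 (`CC(C)[C@@H](c1ccc(-c2ccc3cccc(F)c3c2)[nH]c1=O)[C@H]1OC(=O)NC1=O`) gives > 3 h, which is also a limit. The whole picture so far is the limit of > 3 h in this assay, at which 2 of the 2 values shown sit, so neither compound has an exact half-life.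

Compound 3 (`O=C1NC(=O)/C(=C/C(c2ccccc2)c2ccc(-c3ccc4cccc(F)c4c3)[nH]c2=O)O1`) has phenyl in place of pentan-3-yl on a saturated chain carbon bound to an aromatic carbon and a double-bonded chain carbon. Among the measured compounds shown here, no two measured compounds differ in just one place, so no measured step shows what such a swap does in this assay.

The expectation therefore rests on compound 1 and its limit of > 3 h, and no clear shift in either direction is expected. The expected result is a step that the limit leaves unreadable from compound 1 to compound 3, a step no larger than the usual scatter. For compound 3 the estimated half-life is 3.5 h, with an expected range from 1.5 h to 6 h. The assay may well report only a limit again.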

Compound 3, half-life: 2.1 h
Compound 3: the middle estimate sits 1.7-fold (0.22 log units) above what was measured; measured number inside the range.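

With compound 3, this assay gives an exact half-life for the first time among the compounds shown: with phenyl in place of pentan-3-yl on this saturated chain carbon, compound 3 reaches 2.1 h. Compound 1 gives > 3 h, which is a limit and not a number. The swap can therefore be stated only as an at least 1.4-fold lower number from compound 1 to compound 3 (0.15 log units; that floor lies within the scatter), so this position may tolerate the change with little effect or may respond more strongly, and the true size of the step stays hidden, since most of the values sit at a limit: the limit of > 3 h in this assay, at which 2 of the 3 values shown sit.

The compounds shown leave open whether the result at this carbon follows from having a ring there or from losing the branched pentan-3-yl chain, a question that a cyclohexyl group, which is a ring without aromatic character, or a pyridine ring could help to separate. An exact half-life for compound 1, rather than a limit, would also be needed to show whether phenyl truly shortens the half-life at this position or leaves it unchanged within the usual scatter.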